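The source may hold more compounds than are shown below. What is called first, only, known or untested is meant among the compounds shown, and "the series" means these compounds.

Measured so far:
compound 1 `CC(=O)OC[C@H]1O[C@@H](n2cnc3c(=S)[nH]c(N)nc32)C[C@@H]1OC(C)=O` — a functional assay on L1210 cells (Mus musculus) for inhibition, read by thymidine incorporation; a higher number here means that more compound is needed for the effect, a lower number that less compound is needed: "not determined" (no result reported)
compound 2 `CSc1nc(N)nc2c1ncn2[C@@H]1C[C@H](O)[C@@H](CO)O1` — this assay: > 100 uM
compound 3 `CSc1nc(N)nc2c1ncn2[C@H]1C[C@H](O)[C@@H](CO)O1` — this assay: 27 uM

Compound 2 stands at the bottom of what is known: its entry is a limit of the assay and not a number (the limit of > 100 uM in this assay, at which 1 of the 3 values shown sits). Compound 3 gives a number, and the step of an at least 3.7-fold lower number from compound 2 to compound 3 (0.56 log units; beyond the scatter) rests on the fact that compounds 2 and 3 differ only in the configuration as drawn alone.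

Compound 4 `Cn1cnc([N+](=O)[O-])c1Sc1nc(N)nc2c1ncn2[C@@H]1C[C@H](O)[C@@H](CO)O1` differs from compound 2 by 1-methyl-4-nitro-1H-imidazol-5-yl in place of methyl on a sulfur. Among the measured compounds shown here, no measured step touches the group on the sulfur; the only step in hand, from compound 2 to compound 3, concerns configuration and does not bear on this change. Compound 2 itself offers only a limit, so the expectation is weakly founded. Compound 4 is estimated at 60 uM in this assay, between 10 uM and 300 uM; that estimate means a step of an at least 1.6-fold lower number from compound 2 to compound 4 (0.22 log units; that floor lies within the scatter), and a further limit-only result is quite possible.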

Compound 4, concentration for half-maximal effect: > 100 uM
Compound 4 gave a limit, no number; the forecaster's own chance of this, stated with the estimate: 45%; at least 1.6-fold (0.22 log units) between middle value and limit.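

Compound 2 and compound 4 both give only a limit in this assay, not a number, and no step can be read between them. From the compounds shown here alone, whether 1-methyl-4-nitro-1H-imidazol-5-yl in place of methyl on a sulfur changes the number at all stays open.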